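Dimethylamino in Place of Cyclopentylamino on the Shared Core

A few compounds are considered here, and "the series" means these few. Any claim that something is new, unique, unknown or untested is made for them only; others in the source may bear on it.

Measured so far:
compound 1 `CNC(=O)c1cnc(NC(=O)NC2CCCCC2)n2nc(-c3ccco3)nc12`: 18700 nM
compound 2 `O=C(Nc1ncc(C(=O)O)c2nc(-c3ccco3)nn12)NC1CCCCC1`: 59400 nM
compound 3 `CCOC(=O)c1cnc(NC2CCCC2)n2nc(-c3ccco3)nc12`: 35 nM

In an assay on CHO cells for displacement of a labelled ligand from adenosine receptor A3 (Homo sapiens) (on this read-out higher numbers stand for weaker inhibition and lower numbers for stronger inhibition), compound 3 stands lowest of the three numbers, far beneath compound 1 and compound 2. Compound 4 `CCOC(=O)c1cnc(N(C)C)n2nc(-c3ccco3)nc12` differs from it in one place: dimethylamino in place of cyclopentylamino on an aromatic carbon. Among the measured compounds shown here, the single measured step, a 3.2-fold higher number from compound 1 to compound 2 (0.50 log units; beyond the scatter), alters a different group on the shared core and does not touch the amine, so no measured step bears on this change; the data hold no exchange of one amine for another. Loss of the hydrogen-bond donor counted above is the only guide, and the expectation is a weaker result, with a 20-fold higher number from compound 3 to compound 4 (1.30 log units; beyond the scatter) as the estimated step. Compound 4 is therefore expected to give 700 nM, within 100 nM to 5000 nM.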

Compound 4, inhibition constant: 275 nM
Estimate against measurement, compound 4: 2.5-fold (0.41 log units) above; low and high end bracket the measured number.
By their numbers in this assay, from the lowest: compound 3; then compound 4; then compound 1; then compound 2.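

In this assay the exchange of one amine for another on this aromatic carbon gives a 7.9-fold higher number from compound 3 to compound 4 (0.90 log units; beyond the scatter) and so shows that the number responds to the amine at this position. The change removes the five-membered ring and the hydrogen-bond donor together, so the step cannot be assigned to either one alone. No measurement here accounts for the step. Methylamino, which has no ring but keeps a hydrogen on the nitrogen, could help separate the two, and cyclohexylamino would test a larger ring at this position.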